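Para-methyl on the phenyl of a cytotoxicity-inert pair

A few compounds are considered here, and "the series" means these few. Any claim that something is new, unique, unknown or untested is made for them only; others in the source may bear on it.

Measured compounds in an ADME assay on MDCK cells (Canis lupus familiaris) for cytotoxicity, read by MTT assay, with a stated time of 48 h; on this read-out higher numbers stand for lower toxicity in this test and lower numbers for higher toxicity in this test:
compound 1 `NC(=O)c1c(NC(=O)c2cnn3c(C(F)F)cc(-c4ccccc4)nc23)sc2c1CCCC2`, > 250000 nM
compound 2 `NC(=O)c1c(NC(=O)c2cnn3c(C(F)(F)F)cc(-c4ccccc4)nc23)sc2c1CCCC2`, > 250000 nM

Compound 2 `NC(=O)c1c(NC(=O)c2cnn3c(C(F)(F)F)cc(-c4ccccc4)nc23)sc2c1CCCC2` stands only at a limit of this assay, > 250000 nM. The same holds for compound 1, whose value > 250000 nM is a limit too. Among the compounds with values here, the one measured step, a step that the two limits leave unreadable from compound 1 to compound 2, is therefore unreadable; both values sit at the limit of > 250000 nM in this assay, at which 2 of the 2 values shown sit.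

Compound 3 `Cc1ccc(-c2cc(C(F)(F)F)n3ncc(C(=O)Nc4sc5c(c4C(N)=O)CCCC5)c3n2)cc1` differs from compound 2 by methyl in place of hydrogen on an aromatic carbon. Within the data shown here, no measured step bears on this change, and the measured pair gives no readable size at all. For compound 3 the step that the limit leaves unreadable from compound 2 to compound 3 is expected to leave it beyond the limit again. Compound 3 is estimated at 300000 nM, within 150000 nM to 600000 nM.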

Compound 3, half-maximal cytotoxic concentration: > 250000 nM
Compound 3: a limit, no number; the forecaster's own chance of this, stated with the estimate: 85%; the middle value does not contradict the limit.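

In this assay compound 3 gives > 250000 nM, a limit and not a number. With compound 2 also at a limit, no step can be read for phenyl to 4-methylphenyl. The compounds shown leave open what actual half-maximal cytotoxic concentration any of them has.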